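This account rests on a few compounds, and the source may have more. Where it says the series, first, only, none or still open, it means among the compounds named here.

Compound 1 `O=c1n(Cc2nc3ccc(F)cn3c2CCCCO)c2cnccc2n1C1CC1`: > 100000 nM
Compound 2 `O=c1n(Cc2nc3cc(F)ccn3c2CCCCO)c2cnccc2n1C1CC1`: > 100000 nM

In an ADME assay on HEp-2 cells (Homo sapiens) for cytotoxicity, read by CCK-8 assay, with a stated time of 6 days (on this read-out higher numbers stand for lower toxicity in this test and lower numbers for higher toxicity in this test), compound 1 gives > 100000 nM, which is a limit of the test and not a number. Compound 2 gives > 100000 nM in this assay, again a limit rather than a measured number. Within the data shown here, compound 2 therefore stands at the limit of > 100000 nM in this assay, at which 2 of the 2 values shown sit, and no step between the two measured compounds can be sized.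

Compound 3 `O=c1n(Cc2nc3cc(Cl)ccn3c2CCCCO)c2cnccc2n1C1CC1` has not yet been measured in this assay. It differs from compound 2 as follows: chloro in place of fluoro on an aromatic carbon. Among the measured compounds shown here, no measured step exists for such a change here, so no direction can be read from the data; the expectation is a step of no more than the usual scatter, in either direction. Compound 3 is thus expected to remain at the limit, with an estimated value of 150000 nM and a range from 50000 nM to 400000 nM. This expected outcome corresponds to a step that the limit leaves unreadable from compound 2 to compound 3, which is expected to fall within the scatter because compound 2 already sits at the limit of > 100000 nM in this assay, at which 2 of the 2 values shown sit.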

Compound 3, half-maximal cytotoxic concentration: > 100000 nM
Compound 3 was reported as a limit; the forecaster's own chance of this, stated with the estimate: 80%; the middle value does not contradict the limit.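

No step can be read for chloro in place of fluoro between compound 2 and compound 3, as both results in this assay are limits and not numbers: the limit of > 100000 nM in this assay, at which 3 of the 3 values shown sit.

The compounds shown leave open how any of them would compare with a measured value inside the range of this assay.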